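Benzyloxy in Place of Fluoro: What to Expect

The source may report more compounds than this note shows. Statements on the series, on what has been measured and on what is new or still open speak of the compounds shown alone.

Three compounds have results in a toxicity assay on THP-1 cells (Homo sapiens) for cytotoxicity, read by MTT assay, with a stated time of 72 h; a lower number here means that less compound is needed, a higher number that more compound is needed for the effect. Compound 1 `Cn1c(/C=N/N=C(/N)S)cc2ccccc21` reaches only a limit of the assay, > 200000 nM (the limit of > 200000 nM in this assay, at which 1 of the 3 values shown sits). Compound 2 `Cc1cccc(Cn2cc(/C=N/NC(N)=S)c3ccccc32)c1` gives 32000 nM. Compound 3 `NC(=S)N/N=C/c1ccc(F)c2ccccc12` gives 39000 nM, the higher of the two actual numbers, though its gap to compound 2 lies within the usual scatter. Compound 4 `NC(=S)N/N=C/c1ccc(OCc2ccccc2)c2ccccc12` differs from compound 3 in one place: benzyloxy in place of fluoro on an aromatic carbon. Within the data shown here, no step between measured compounds shows how such a swap moves the read-out, so any expectation rests only on compound 2 and compound 3 sitting close together. For compound 4 a step of a 1.6-fold lower number from compound 3 to compound 4 (0.19 log units; within the scatter) is estimated, toward a lower number but not beyond the scatter. Compound 4 is thus expected to give about 25000 nM, within 8000 nM to 80000 nM.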

Compound 4, half-maximal effective concentration: 27000 nM
Estimate against measurement, compound 4: 1.1-fold (0.03 log units) below; the measured number falls inside the stated range.
By their numbers in this assay, from the lowest: compounds 4, 2 and 3 (each within the scatter of the next). At a limit, above all of these: compound 1.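

In this assay, among these compounds, the only step read at this aromatic carbon is a 1.4-fold lower number from compound 3 to compound 4 (0.16 log units; within the scatter). Replacing fluoro with benzyloxy, which is far larger and brings an aromatic ring of its own, therefore does not move the number beyond the scatter. Nothing in the data at hand accounts for this result. On these data alone, whether an amine or a carboxylic acid on this carbon would leave the number just as unmoved remains open. So does whether the same swap would behave alike on the core of compound 1 or compound 2.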